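Thiazole for phenyl: clearance outlook for compound 4

The source may hold more compounds than are shown below. What is called first, only, known or untested is meant among the compounds shown, and "the series" means these compounds.

Measured so far in an ADME assay on microsomes from liver (Mus musculus) for metabolic stability; a lower number here means slower removal, a higher number faster removal of the compound:
compound 1 `CN1C(=O)C2=C(C1=O)N(CC(=O)Nc1ccc(-c3ccccc3)cc1)CCC2` gives 25 mL.min-1.g-1 in mouse liver microsomes
compound 2 `CN1C(=O)C2=C(C1=O)N(CC(=O)Nc1ccc(-c3cccnc3)nc1)CCC2` gives 17 mL.min-1.g-1 in mouse liver microsomes
compound 3 `CN1C(=O)C2=C(C1=O)N(CC(=O)Nc1ccc(-c3cccnc3)nn1)CCC2` gives 12 mL.min-1.g-1 in mouse liver microsomes

Compound 1 and compound 2 lie within the scatter of each other. Compound 3 has a lower number than compound 1, and that gap lies beyond the scatter, so compound 1 sits at the upper end of this small set, level with compound 2.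

The next compound, compound 4 `CN1C(=O)C2=C(C1=O)N(CC(=O)Nc1ccc(-c3nccs3)cc1)CCC2`, keeps the core of compound 1 and carries 1,3-thiazol-2-yl in place of phenyl on an aromatic carbon at a site para to a large group.

For the measured compounds named here, no measured pair isolates this change, since compound 2 and compound 3 each differ from compound 1 in more than one place. Going by the values given here, the only guide is that compound 2 at 17 mL.min-1.g-1 and compound 3 at 12 mL.min-1.g-1 do not exceed compound 1 in this set. A small lowering is therefore expected, estimated as a 1.4-fold lower number from compound 1 to compound 4 (0.14 log units; within the scatter) and probably within the scatter. For compound 4 the expected value is 18 mL.min-1.g-1 (estimated range 9 mL.min-1.g-1 to 35 mL.min-1.g-1) in this assay on this reasoning.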

Compound 4, intrinsic clearance in microsomes: 65 mL.min-1.g-1
Beside the measured number, compound 4's estimate is 3.6-fold (0.56 log units) below it, outside the stated range (above it).
By their numbers in this assay, from the lowest: compounds 3, 2 and 1 (each within the scatter of the next, the first and the last beyond it); then compound 4.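

In this assay, the site on the aromatic carbon of the six-membered ring, para to a large group, proves sensitive to the ring it carries: with the shared core held fixed, 1,3-thiazol-2-yl in place of phenyl gives a 2.6-fold higher number from compound 1 to compound 4 (0.41 log units; beyond the scatter). For the compounds shown here, this is the first step that isolates a single change, and it shows that replacing phenyl with this five-membered aromatic ring moves the number towards faster removal, a step that lies beyond the usual scatter. Nothing available accounts for the rise, and the data do not show which part of the molecule is affected.

Open, going by these compounds, is whether an oxazole ring or a pyrazole ring at the same place on the same core would stay level with compound 1 or move with compound 4, and whether a methyl group or a chlorine on the thiazole would shift the number. On these data alone, compound 2 and compound 3 each differ from compound 1 in more than one place, and the separate contribution of each of those changes also stays open.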